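The source may hold more compounds than are shown below. What is called first, only, known or untested is meant among the compounds shown, and "the series" means these compounds.

Working notes on the series. Three compounds have numbers in an assay on CHO cells for displacement of a labelled ligand from Glucagon receptor (Homo sapiens), read by scintillation counting, with a stated time of 60 min; a higher number here means a weaker inhibitor, a lower number a stronger inhibitor. Compound 1 `C[C@H](c1ccc(C(=O)NCCC(=O)O)cc1)N1C(=O)C(c2ccc(F)cc2)=N[C@]12CC[C@@H](C(C)(C)C)CC2` gives 85 nM in this assay. Compound 2 `CC(C)(C)CC[C@H](c1ccc(C(=O)NCc2nn[nH]n2)cc1)N1C(=O)C(c2cncc(Cl)c2)=N[C@]12CC[C@@H](C(C)(C)C)CC2` gives 38 nM in this assay. Compound 3 `CC[C@H]1CC[C@]2(CC1)N=C(c1cc(Cl)cc(Cl)c1)C(=O)N2[C@H](CCC(C)(C)C)c1ccc(C(=O)NCc2nn[nH]n2)cc1` gives 44 nM in this assay, which is the second highest of the three numbers; its nearest neighbour is compound 2, with a gap that lies within the scatter, and its furthest is compound 1, with a gap that also lies within the scatter. For the measured compounds named here, no pair of measured compounds differs in a single place, so the three values are read only as a spread that does not separate the compounds from one another.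

The step under consideration leads from compound 3 to compound 4 `CC(C)(C)CC[C@H](c1ccc(C(=O)NCc2nn[nH]n2)cc1)N1C(=O)C(c2cc(Cl)cc(Cl)c2)=NC12CCCCC2`, which has not yet been measured: hydrogen in place of ethyl on a saturated ring carbon. Going by the values given here, none of the measured compounds tests this change directly. The expected step from compound 3 to compound 4 is small, a 1.8-fold higher number from compound 3 to compound 4 (0.26 log units; within the scatter), toward a somewhat higher number in this assay but not clearly beyond the scatter. Compound 4 is accordingly expected to give about 80 nM in this assay, within a range of 30 nM to 250 nM.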

Compound 4, half-maximal inhibitory concentration: 195 nM
Beside the measured number, compound 4's estimate is 2.4-fold (0.39 log units) below it; measured number inside the range.
By their numbers in this assay, from the lowest: compounds 2, 3 and 1 (each within the scatter of the next, the first and the last beyond it); then compound 4.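

In this assay, for the compounds shown here, hydrogen in place of ethyl on this saturated ring carbon gives a 4.4-fold higher number from compound 3 to compound 4 (0.65 log units; beyond the scatter), and this is the only single-place comparison. In this pair, therefore, the ring carbon three ring bonds from the ring atom that bears two fused rings is a place where the substituent shows in the number, which compounds 1, 2 and 3 could not reveal, as no two of them differ in one place alone. No evidence at hand accounts for the size of this step.

Open, going by these compounds, is whether a methyl group, a propyl chain or a hydroxyl group on the same carbon would give a number close to that of compound 3 at 44 nM. Also open, on these data alone, is whether the step carries over when other parts of the molecule differ.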